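The compounds below may be only part of what the source reports. "The series", "measured", "known", "first", "only" and "open" are said of these compounds alone.

In an ADME assay on L6 cells (Rattus norvegicus) for cytotoxicity, read by resazurin assay, with a stated time of 72 h; on this read-out higher numbers stand for weaker inhibition and lower numbers for stronger inhibition:
- compound 1 `CN(C)C12CC(c3ccccc3)C(CN(C(=O)CN3CCCC3)C1)C(c1ccccc1)C2`: 12600 nM
- compound 2 `CCN(CC)CCC(=O)N1CC2C(c3ccccc3)CC(N(C)C)(CC2c2ccccc2)C1`: 15400 nM

Among the compounds with values here, compound 2 stands level with the only other measured compound. Within the data shown here, the single measured step, a 1.2-fold higher number from compound 1 to compound 2 (0.09 log units; within the scatter), puts (diethylamino)methyl in place of pyrrolidin-1-yl on a saturated chain carbon bound to a carbonyl carbon.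

Compound 3 `CN(C)C12CC(c3ccccc3)C(CN(CCCN3CCCC3)C1)C(c1ccccc1)C2` differs from compound 2 by 3-(pyrrolidin-1-yl)propyl in place of (2-(diethylamino)ethyl)carbonyl on an amine nitrogen in a ring. Among the measured compounds shown here, no measured step covers loss of the carbonyl, so guidance is weak. A modest move to a lower number in this assay is tentatively expected, as a 1.9-fold lower number from compound 2 to compound 3 (0.28 log units; within the scatter). For compound 3 the estimated value is 8000 nM, with an expected range of 2500 nM to 25000 nM.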

Compound 3, half-maximal inhibitory concentration: 1550 nM
Beside the measured number, compound 3's estimate is 5.2-fold (0.71 log units) above it; measured number outside the range, below it.
By their numbers in this assay, from the lowest: compound 3; then compounds 1 and 2 (each within the scatter of the next).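

Within the data shown here, on the amine nitrogen in a ring, the acyl side chains of the earlier compounds gave no separable numbers in this assay, yet 3-(pyrrolidin-1-yl)propyl shifts the read-out beyond the scatter against both (a 9.9-fold lower number from compound 2 to compound 3 (1.00 log units; beyond the scatter); an 8.1-fold lower number from compound 1 to compound 3 (0.91 log units; beyond the scatter)). This position therefore responds to this change, and both steps point to stronger inhibition in this cytotoxicity read-out. No supporting measurement accounts for the shift.

From the compounds shown here alone, neither step removes the carbonyl alone, so its share stays open. A 3-(diethylamino)propyl group or a piperidine at the chain end would help separate it.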